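The source may hold more compounds than are shown below. What is called first, only, known or untested is meant among the compounds shown, and "the series" means these compounds.

In a physicochemical assay, with a stated time of 50 min (on this read-out higher numbers stand for weaker inhibition and lower numbers for stronger inhibition), compound 1 `O=C(O)[C@@H]1CSC(c2c(F)cccc2F)N1` gives 343000 nM as a measured number. Compound 2 `N#Cc1ccccc1C1N[C@H](C(=O)O)CS1` shows > 1000000 nM as a limit of the assay and not a number. Compound 3 `Cc1ccccc1C1N[C@H](C(=O)O)CS1` differs from compound 2 by methyl in place of cyano on an aromatic carbon and has not yet been measured. Among the measured compounds shown here, no measured pair shows this change, so the only number to lean on is that of compound 1 at 343000 nM in this assay on a related structure. A modest move toward stronger inhibition is therefore expected, with an at least 1.6-fold lower number from compound 2 to compound 3 (0.22 log units; that floor lies within the scatter) as the estimated step. Compound 3 is estimated at 600000 nM with 200000 nM to 1500000 nM as the expected range.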

Compound 3, half-maximal inhibitory concentration: 46100 nM
Compound 3: the middle estimate sits 13-fold (1.11 log units) above what was measured; the whole stated range lies above it.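

Methyl in place of cyano on an aromatic carbon gives an at least 21-fold lower number from compound 2 to compound 3 (1.33 log units; beyond the scatter) in this assay, so what sits on this carbon can matter a great deal for inhibition. The true size of the step remains uncertain, since compound 2 has a limit of the assay and not a number: the limit of > 1000000 nM in this assay, at which 1 of the 3 values shown sits.

With only cyano and methyl shown here, it remains open how an amine, a methoxy group or a longer chain on this carbon would compare. From the compounds shown here alone, whether methyl would give a similar step on another carbon of the ring also remains open.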